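Phenethyl for 4-methoxyphenyl on a sulfur

The source may report more compounds than this note shows. Statements on the series, on what has been measured and on what is new or still open speak of the compounds shown alone.

Compound 1 `COc1ccc(SCc2ccc(C(=O)Nc3ccccc3N)cc2)cc1`: 2390 nM
Compound 2 `Nc1ccccc1NC(=O)c1ccc(CSc2nccc(C(F)(F)F)n2)cc1`: 1140 nM
Compound 3 `Nc1ccccc1NC(=O)/C=C/c1ccc(CSCCc2ccccc2)cc1`: "not determined" (no result reported)

In a functional assay on HeLa cells (Homo sapiens) for antiproliferative activity, read by CCK-8 assay, with a stated time of 72 h (a lower number here means a stronger inhibitor, a higher number a weaker inhibitor), compound 1 stands highest of the two numbers, at 2390 nM. Compound 2 lies nearest at 1140 nM, a gap just beyond the scatter. Compound 3 offers no number for comparison. Compound 4 `Nc1ccccc1NC(=O)c1ccc(CSCCc2ccccc2)cc1` differs from compound 1 by phenethyl in place of 4-methoxyphenyl on a sulfur. Going by the values given here, no measured pair isolates this change, so the only guide is how close together compound 1 at 2390 nM and compound 2 at 1140 nM lie. In this assay, the expected step of a 1.2-fold lower number from compound 1 to compound 4 (0.08 log units; within the scatter) stays within the scatter. For compound 4 the estimated value is 2000 nM, with an expected range from 700 nM to 6000 nM.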

Compound 4, half-maximal inhibitory concentration: 6430 nM
For compound 4 the middle estimate is 3.2-fold (0.51 log units) below the measured one, outside the stated range (above it).
By their numbers in this assay, from the lowest: compound 2; then compound 1; then compound 4.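

In this assay, placing phenethyl instead of 4-methoxyphenyl on the sulfur gives a 2.7-fold higher number from compound 1 to compound 4 (0.43 log units; beyond the scatter), so this position responds to the group it carries. The two groups match in heavy-atom number and aromatic ring count, and differ in those counts only in that an oxygen and its hydrogen-bond acceptor give way to a carbon. Nothing measured here bears on why the number rose. Still open, as far as these compounds go, is whether a plain phenyl or a 4-aminophenyl on the sulfur would sit nearer compound 1 or compound 4.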